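Notes on a pyridin-3-yl exchange

The source may hold more compounds than are shown below. What is called first, only, known or untested is meant among the compounds shown, and "the series" means these compounds.

In a functional assay on K562 cells (Homo sapiens) for inhibition, read by MTT assay, with a stated time of 48 h (on this read-out higher numbers stand for weaker inhibition and lower numbers for stronger inhibition), compound 1 (`CS(=O)(=O)Nc1ccc(-c2cccc(C(=O)N[C@H]3CN[C@@H](C(=O)Nc4ccc(Cl)c(C(F)(F)F)c4)C3)c2)cn1`) gives 24600 nM. Compound 2 (`CCN(CC)C(=O)c1cncc(-c2ccc(C(=O)N[C@@H](C)C(=O)Nc3ccc(Cl)c(C(F)(F)F)c3)cc2)c1`) gives 20200 nM, and compound 3 (`CS(=O)(=O)Nc1ccc(-c2ccc(C(=O)N[C@H]3CN[C@@H](C(=O)Nc4ccc(Cl)c(C(F)(F)F)c4)C3)cc2)cn1`) gives 45000 nM. Compound 1 holds the middle number of the three, but its gaps to compound 2 and to compound 3 both lie within the scatter.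

Compound 4 (`O=C(NC1CC1)c1cncc(-c2cccc(C(=O)N[C@H]3CN[C@@H](C(=O)Nc4ccc(Cl)c(C(F)(F)F)c4)C3)c2)c1`) keeps the core of compound 1 and carries 5-(cyclopropylcarbamoyl)pyridin-3-yl in place of 6-(methanesulfonamido)pyridin-3-yl, on an aromatic carbon, meta to a large group (5-(cyclopropylcarbamoyl)pyridin-3-yl in place of 6-(methanesulfonamido)pyridin-3-yl on an aromatic carbon). Going by the values given here, no measured pair here differs in one place only, so the size of this exchange has no direct precedent. The expectation rests only on how close the three measured numbers lie, and no shift beyond the scatter is expected in this assay. The estimated change is a 1.0-fold lower number from compound 1 to compound 4 (0.01 log units; within the scatter), expected to remain within the scatter. Compound 4 is estimated at 24000 nM, with an expected range of 10000 nM to 55000 nM.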

Compound 4, half-maximal inhibitory concentration: 27300 nM
Compound 4: the middle estimate sits 1.1-fold (0.06 log units) below what was measured, within the range that was stated.
By their numbers in this assay, from the lowest: compounds 2, 1, 4 and 3 (each within the scatter of the next, the first and the last beyond it).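

In this assay, going by these compounds alone, 5-(cyclopropylcarbamoyl)pyridin-3-yl in place of 6-(methanesulfonamido)pyridin-3-yl, on an aromatic carbon, meta to a large group, gives the first step in this set that differs in one place only: a 1.1-fold higher number from compound 1 to compound 4 (0.05 log units; within the scatter). This read-out therefore does not separate the two groups at this position, although the exchange removes the methanesulfonamido group and brings in a three-membered non-aromatic ring of carbon only. No measurement shown here offers an explanation for this result.

As far as these compounds go, whether a carboxylic acid or a primary amine on the pyridin-3-yl ring at this position would give a step beyond the scatter remains open. Also open, from the compounds shown here alone, is whether an exchange elsewhere on the core of compound 1 would do so.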